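The compounds below may be only part of what the source reports. "The series", "measured", "known", "first", "only" and "open" are said of these compounds alone.

In a functional assay on CAL-27 cells (Homo sapiens) for cytotoxicity, read by MTT assay, with a stated time of 72 h (on this read-out higher numbers stand for weaker inhibition and lower numbers for stronger inhibition), compound 1 `Cc1cc(C)cc(C(=O)N(CC(=O)NCc2ccccc2)Cc2ccc(C(=O)Nc3cc(F)ccc3N)cc2)c1` gives 5720 nM, the lowest of the three numbers measured, against compound 2 `Cc1cc(C)cc(C(=O)N(CCCCCC(=O)Nc2ccccc2N)CC(=O)NCc2ccccc2)c1` at 13700 nM and compound 3 `Cc1cc(C)cc(CNC(=O)CN(CCCCCC(=O)Nc2ccccc2N)C(=O)c2cc(C)cc(C)c2)c1` at 19300 nM. Compound 4 `Cc1cc(C)cc(C(=O)N(CC(=O)NCc2ccccc2)Cc2ccc(C(=O)Nc3ccccc3N)cc2)c1` differs from compound 1 in a single place, with hydrogen in place of fluoro on an aromatic carbon. For the measured compounds named here, the only measured step, a 1.4-fold higher number from compound 2 to compound 3 (0.15 log units; within the scatter), concerns a different part of the structure and stays within the scatter. Going by the values given here, no measured pair isolates the loss of the fluoro group, so no step beyond the scatter is expected in this assay. The expected change is a 1.1-fold higher number from compound 1 to compound 4 (0.06 log units; within the scatter). For compound 4 the estimated value is 6500 nM, with an expected range from 2700 nM to 15000 nM.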

Compound 4, half-maximal inhibitory concentration: 1600 nM
Compound 4: the middle estimate sits 4.1-fold (0.61 log units) above what was measured; measured number below the stated range.
By their numbers in this assay, from the lowest: compound 4; then compound 1; then compounds 2 and 3 (each within the scatter of the next).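

Taking away the fluoro group gives a 3.6-fold lower number from compound 1 to compound 4 (0.55 log units; beyond the scatter) in this assay, so this single change, on an aromatic carbon para to the amino group, moves the number beyond the scatter, whereas the only earlier step stayed within it. On this shared core, the 2-aminophenyl compound therefore reads as the stronger inhibitor than the 2-amino-5-fluorophenyl compound. Nothing available accounts for this step. On these data alone, whether a chloro or methoxy group at this place would read closer to compound 1 or to compound 4 stays open. So does whether the same change would give a similar step on the chain of compound 2.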